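The source may hold more compounds than are shown below. What is called first, only, known or untested is meant among the compounds shown, and "the series" means these compounds.

Measured so far:
Compound 1 `Cc1c(Oc2cnc(C(=O)NC(C)CO)cn2)ccc2c1B(O)OC2`: 85%
Compound 2 `Cc1c(Oc2cnc(C(=O)N[C@@H](CO)CC(F)(F)F)cn2)ccc2c1B(O)OC2`: 64%

In an ADME assay on the whole organism (strain CD1) for pharmacokinetics, with Mus musculus as the target, read by LC-MS, at a dose of 5 mg/kg by the oral route (a lower number here means that a smaller share of the oral dose reaches the circulation, a higher number that a larger share of the oral dose reaches the circulation), compound 2 stands lowest of the two at 64%, and compound 1 gives 85%, a gap beyond the scatter. The next compound, compound 3 `Cc1c(Oc2cnc(C(=O)N3CC(C)(O)C3)cn2)ccc2c1B(O)OC2`, has not yet been measured. It differs from compound 2 as follows: 3-hydroxy-3-methylazetidin-1-yl in place of (3,3,3-trifluoro-1-(hydroxymethyl)propyl)amino on a carbonyl carbon.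

Among the compounds with values here, one measured step bears on this change: a number 21 percentage points lower from compound 1 to compound 2 (beyond the scatter). That step is modest but beyond the scatter, and it came with the 3,3,3-trifluoro-1-(hydroxymethyl)propyl chain that compound 3 gives up. Within the data shown here, no measured compound yet carries the 3-hydroxy-3-methylazetidin-1-yl group, so this step offers only a loose guide. A modest rise is therefore expected: a number 10 percentage points higher from compound 2 to compound 3 (within the scatter). For compound 3 the estimated value is 74%, with an expected range of 52% to 93%.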

Compound 3, oral bioavailability: 101%
The estimate for compound 3 lay 27 percentage points below the measured number; measured number above the stated range.
By their numbers in this assay, from the lowest: compound 2; then compound 1; then compound 3.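

In this assay, the 3-hydroxy-3-methylazetidin-1-yl group on the carbonyl carbon gives a number 37 percentage points higher from compound 2 to compound 3 (beyond the scatter), and in place of the (1-(hydroxymethyl)ethyl)amino group it gives a number 16 percentage points higher from compound 1 to compound 3 (beyond the scatter). The earlier compounds shown here showed only a fall between two open-chain amides, whereas these steps show that a four-membered ring can stand at this place and that it gives a higher number than either open chain, not only the fluorinated one. Nothing available here accounts for these rises.

The compounds shown do not separate the ring itself from the hydroxyl and methyl groups it carries, since they include neither the unsubstituted azetidin-1-yl nor 3-hydroxyazetidin-1-yl, nor a pyrrolidine as a larger ring. All three share the same core, so they also leave open whether the ring would give the same rise on a different one.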